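The source may hold more compounds than are shown below. What is called first, only, known or untested is meant among the compounds shown, and "the series" means these compounds.

Measured so far:
compound 1 `Nc1cc(N)c2nc(-c3ccccc3)c(Oc3ccc(Cl)c(Cl)c3)nc2c1` — < 100000 nM
compound 2 `CCOC(=O)[C@H](CCC(=O)O)NC(=O)c1ccc(Sc2nc3cc(N)cc(N)c3nc2-c2ccccc2)cc1` — < 100000 nM
compound 3 `CCOC(=O)[C@H](CCC(=O)O)NC(=O)c1ccc(Oc2nc3cc(N)cc(N)c3nc2-c2ccccc2)cc1` — < 100000 nM

All three were tested in a functional assay on MOLT-4 cells (Homo sapiens) for inhibition, read by sulforhodamine B assay, with a stated time of 48 h; on this read-out higher numbers stand for weaker inhibition of growth and lower numbers for stronger inhibition of growth. For compound 1 the value < 100000 nM is a limit of the assay, not a number. For compound 2 the value < 100000 nM is likewise a limit. For compound 3 the value < 100000 nM is also a limit. Going by the values given here, compound 1 therefore stands at the same limit as the other two; the only thing known is the limit of < 100000 nM in this assay, at which 3 of the 3 values shown sit, which gives no ordering among them and no measured step to lean on.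

Compound 4 `Nc1cc(N)c2nc(-c3ccccc3)c(Sc3ccc(F)cc3)nc2c1` has not yet been measured in this assay. Its change from compound 1 is (4-fluorophenyl)sulfanyl in place of 3,4-dichlorophenoxy on an aromatic carbon, in words (4-fluorophenyl)sulfanyl in place of 3,4-dichlorophenoxy on an aromatic carbon. Among the compounds with values here, no step between measured compounds is available to size such a change, so the expected step that the limit leaves unreadable from compound 1 to compound 4 is taken as none beyond the scatter. Compound 4 is expected to give 30000 nM, in the range 5000 nM to 100000 nM, and most probably again only a limit.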

Compound 4, concentration for total growth inhibition: < 100000 nM
Compound 4 ended at the assay's limit; the forecaster's own chance of this, stated with the estimate: 70%; the middle value does not contradict the limit.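

Going by these compounds alone, compound 1 and compound 4 both end at a limit, not a number, so no step between them can be read: the limit of < 100000 nM in this assay, at which 4 of the 4 values shown sit.

As far as these compounds go, how the four compounds rank in this assay, and whether (4-fluorophenyl)sulfanyl in place of 3,4-dichlorophenoxy changes growth inhibition at all, stays open.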